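Iodo for isopropyl on a longer chloroalkyl amide

This account rests on a few compounds, and the source may have more. Where it says the series, first, only, none or still open, it means among the compounds named here.

Three compounds share one core and were measured in a functional assay on MCF7 cells (Homo sapiens) for antiproliferative activity, read by sulforhodamine B assay, with a stated time of 48 h; a lower number here means a stronger inhibitor, a higher number a weaker inhibitor. Compound 1 `CC(C)c1ccccc1OS(=O)(=O)c1ccc(NC(=O)CCl)cc1` gives 2900 nM. Compound 2 `O=C(CCl)Nc1ccc(S(=O)(=O)Oc2ccccc2I)cc1` gives 2500 nM; it differs from compound 1 by iodo in place of isopropyl on an aromatic carbon, and the step is a 1.2-fold lower number from compound 1 to compound 2 (0.06 log units; within the scatter). Compound 3 `CC(C)c1ccccc1OS(=O)(=O)c1ccc(NC(=O)CCCCl)cc1` gives 5200 nM, differing from compound 1 by 2-chloroethyl in place of chloro on a saturated chain carbon bound to a carbonyl carbon, with a step of a 1.8-fold higher number from compound 1 to compound 3 (0.25 log units; within the scatter). Compound 4 `O=C(CCCCl)Nc1ccc(S(=O)(=O)Oc2ccccc2I)cc1` is not yet measured. It differs from compound 3 by iodo in place of isopropyl on an aromatic carbon, the same change that turned compound 1 into compound 2, made on a core that differs as described by 2-chloroethyl in place of chloro on a saturated chain carbon bound to a carbonyl carbon. Because that earlier step was a 1.2-fold lower number from compound 1 to compound 2 (0.06 log units; within the scatter), the step from compound 3 to compound 4 is expected to be similar, about a 1.2-fold lower number from compound 3 to compound 4 (0.07 log units; within the scatter). Compound 4 is therefore estimated at 4400 nM, between 2400 nM and 8000 nM.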

Compound 4, half-maximal inhibitory concentration: 6300 nM
Compound 4: middle estimate off by 1.4-fold (0.16 log units), on the low side; measured number inside the range.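

In this assay, iodo in place of isopropyl again makes little difference on the core with the longer chain, at a 1.2-fold higher number from compound 3 to compound 4 (0.08 log units; within the scatter), and the two cores agree on this change: the same change on two cores in this assay, a 1.2-fold lower number (0.06 log units; within the scatter) from compound 1 to compound 2 and a 1.2-fold higher number (0.08 log units; within the scatter) from compound 3 to compound 4, 1.4-fold (0.15 log units) apart, within the scatter of two such steps. Setting 2-chloroethyl in place of chloro gives a 2.5-fold higher number from compound 2 to compound 4 (0.40 log units; beyond the scatter), and this modest step also agrees with its counterpart on the core of compound 1: the same change on two cores in this assay, a 1.8-fold higher number (0.25 log units; within the scatter) from compound 1 to compound 3 and a 2.5-fold higher number (0.40 log units; beyond the scatter) from compound 2 to compound 4, 1.4-fold (0.15 log units) apart, within the scatter of two such steps. Both changes therefore carried across within this set of compounds, but two pairs do not show that they would do so on other cores.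

From the compounds shown here alone, what an amine or a methoxy group would do in place of iodo remains open. So does the effect of a longer chain on the amide.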